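A few compounds are considered here, and "the series" means these few. Any claim that something is new, unique, unknown or untested is made for them only; others in the source may bear on it.

Measured compounds:
compound 1, `C[C@@H](NC(=O)Nc1ccccc1Cl)c1ccccc1`, 93%
compound 2, `C[C@H](NC(=O)Nc1cccc(Cl)c1)c1ccccc1`, 103%
compound 3, `C[C@H](NC(=O)Nc1cc(Cl)ccc1Cl)c1ccccc1`, 100%

In an ADME assay on the whole organism with Oryza sativa as the target, tested at 10 uM (a lower number here means a stronger effect, a higher number a weaker effect of the compound at the concentration tested), compound 1 gives 93%, compound 2 gives 103% and compound 3 gives 100%. The three values lie within the usual scatter of one another, so none of the three can be set apart from the others. Compound 1 and compound 2 have the same atoms joined differently; the difference between the two cores is not broken down here. Compound 2 and compound 3 differ by chloro in place of hydrogen on an aromatic carbon, and this change made a number 3 percentage points lower from compound 2 to compound 3 (within the scatter).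

The unmeasured compound 4, `C[C@@H](NC(=O)Nc1c(Cl)cccc1Cl)c1ccccc1`, differs from compound 1 by chloro in place of hydrogen on an aromatic carbon. Among the compounds with values here, this is the same kind of change as the one from compound 2 to compound 3, though not the same: there the entering chloro sits para to a chloro group, here it sits meta to a chloro group. Because the earlier step was a number 3 percentage points lower from compound 2 to compound 3 (within the scatter), the step is expected to be a number 2 percentage points higher from compound 1 to compound 4 (within the scatter). Compound 4 is therefore estimated at 95%, between 82% and 108%.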

Compound 4, a percentage reported as activity, at one concentration (the size of the read-out at that concentration, not a potency): 100%
For compound 4 the middle estimate is 5 percentage points below the measured one; the measured number falls inside the stated range.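

In this assay, chloro in place of hydrogen on an aromatic carbon made a number 7 percentage points higher from compound 1 to compound 4 (within the scatter). Set beside the same change on the other core, this step cannot be told apart from the earlier one: the same change on two cores in this assay, a number 3 percentage points lower (within the scatter) from compound 2 to compound 3 and a number 7 percentage points higher (within the scatter) from compound 1 to compound 4, 10 percentage points apart, within the scatter of two such steps. Within the data shown here, this shows that, on these two cores, the change produced no step that stands clear of the scatter, and that the core gave no detectable difference in its outcome; it does not show that the change carries over with a fixed size or direction, as neither step can be read as a real effect, two steps are few, and the entering chloro does not stand in the same relation to the existing chloro on the two cores.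

The compounds shown leave open whether a different group on the aromatic ring, such as a nitrile, an amine or a carboxylic acid, would shift the read-out beyond the scatter in this assay. As far as these compounds go, whether a longer chain in place of the methyl group on the shared core would do so also remains open.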